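From a methyl group to trifluoromethyl on the aryl amine

This account rests on a few compounds, and the source may have more. Where it says the series, first, only, none or still open, it means among the compounds named here.

Measured in a functional assay on A549 cells (Homo sapiens) for antiproliferative activity, read by MTT assay, with a stated time of 72 h; on this read-out higher numbers stand for weaker inhibition and lower numbers for stronger inhibition:
- Compound 1 `COc1cc2ncnc(Nc3cccc(F)c3)c2cc1OCCCCC(=O)Nc1ccc(S(N)(=O)=O)cc1` gives only a limit, > 40000 nM.
- Compound 2 `COc1cc2ncnc(Nc3ccc(F)cc3)c2cc1OCCCCC(=O)Nc1ccc(S(N)(=O)=O)cc1` also gives only a limit, > 40000 nM.
- Compound 3 `COc1cc2ncnc(Nc3cccc(C)c3)c2cc1OCCCCC(=O)Nc1ccc(S(N)(=O)=O)cc1` gives 16000 nM.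

Among the measured compounds shown here, compound 3 is thus the only compound with an actual number; the other two sit at a limit. The step that the two limits leave unreadable from compound 1 to compound 2 cannot be read because of the limit of > 40000 nM in this assay, at which 2 of the 3 values shown sit. The steps of an at least 2.5-fold lower number from compound 1 to compound 3 (0.39 log units; beyond the scatter) and an at least 2.5-fold lower number from compound 2 to compound 3 (0.39 log units; beyond the scatter) show that replacing fluoro with methyl brought the number into the measurable range.

Compound 4 `COc1cc2ncnc(Nc3ccc(C(F)(F)F)cc3)c2cc1OCCCCC(=O)Nc1ccc(S(N)(=O)=O)cc1` differs from compound 3 by 4-(trifluoromethyl)phenyl in place of 3-methylphenyl on a nitrogen on an aromatic ring. For the measured compounds named here, no measured step covers trifluoromethyl itself; fluorine, however, appears only in the two compounds that stayed at the limit. Compound 4 is therefore expected to move back towards weaker inhibition in this assay, an estimated step of a 1.9-fold higher number from compound 3 to compound 4 (0.27 log units; within the scatter). Compound 4 is estimated at 30000 nM, within 9000 nM to 80000 nM.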

Compound 4, half-maximal inhibitory concentration: 14800 nM
The estimate for compound 4 lay 2.0-fold (0.31 log units) above the measured number; the range from low to high includes it.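

Fluorine in the group on the nitrogen therefore does not by itself hold a compound at the limit: trifluoromethyl in place of fluoro gives an at least 2.7-fold lower number from compound 2 to compound 4 (0.43 log units; beyond the scatter), and the change of the whole aryl group gives an at least 2.7-fold lower number from compound 1 to compound 4 (0.43 log units; beyond the scatter). Both sizes are only minimum sizes: the limit of > 40000 nM in this assay, at which 2 of the 4 values shown sit. The 3-methylphenyl and 4-(trifluoromethyl)phenyl groups cannot be told apart, with a 1.1-fold lower number from compound 3 to compound 4 (0.03 log units; within the scatter). From the compounds shown here alone, it stays open how an amine or a carboxylic acid in place of trifluoromethyl would read, and whether 3-(trifluoromethyl)phenyl would match 4-(trifluoromethyl)phenyl.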